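The source may hold more compounds than are shown below. What is called first, only, known or untested is meant among the compounds shown, and "the series" means these compounds.

The measured compounds: compound 1, `O=C(Nc1cccc(C(F)(F)F)c1)N[C@H]1CC[C@H](Oc2cccc(F)c2)CC1`, gives 2400 nM in a functional assay on CRL2813 cells (Homo sapiens) for cytotoxicity, read by sulforhodamine B assay, with a stated time of 5 days; on this read-out higher numbers stand for weaker inhibition and lower numbers for stronger inhibition; compound 3, `O=C(Nc1ccc([N+](=O)[O-])cc1)N[C@H]1CC[C@H](Oc2ccc(F)cc2)CC1`, gives 2300 nM; compound 2, `O=C(Nc1ccccc1C(=O)O)N[C@H]1CC[C@@H](Oc2ccc(F)cc2)CC1`, reaches only a limit of > 20000 nM. For compound 2 that limit is described by the limit of > 20000 nM in this assay, at which 1 of the 3 values shown sits.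

On the numbers shown, compound 1 stands at the higher of the two numeric values, yet its gap to compound 3 lies within the scatter, so the two cannot be ordered. Compound 4, `O=C(Nc1cccc(C(F)(F)F)c1)N[C@H]1CC[C@H](Oc2ccccc2C(F)(F)F)CC1`, is not yet measured. It differs from compound 1 in one place: 2-(trifluoromethyl)phenyl in place of 3-fluorophenyl on an oxygen on a saturated carbon. Among the compounds with values here, no measured pair shows this change alone, so in this assay a step of moderate size in either direction, or none beyond the scatter, is expected. Compound 4 is estimated at 3000 nM, within 800 nM to 12000 nM, an expected step of a 1.3-fold higher number from compound 1 to compound 4 (0.10 log units; within the scatter).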

Compound 4, half-maximal inhibitory concentration: 1400 nM
Compound 4: middle estimate off by 2.1-fold (0.33 log units), on the high side; the measured number falls inside the stated range.
By their numbers in this assay, from the lowest: compounds 4, 3 and 1 (each within the scatter of the next). At a limit, above all of these: compound 2.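

In this assay, exchanging 3-fluorophenyl for 2-(trifluoromethyl)phenyl on an oxygen on a saturated carbon gives a 1.7-fold lower number from compound 1 to compound 4 (0.23 log units; within the scatter). This single pair therefore shows that this place takes a group with more heavy atoms, and with its substituent named differently on the ring, without a difference that can be read. Nothing among the data shown accounts for the size of this step. From the compounds shown here alone, whether a pyridine ring or a plain alkyl chain on that oxygen would move the number beyond the scatter stays open.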